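Working notes: 4-aminophenyl to 3-aminophenyl

The source may report more compounds than this note shows. Statements on the series, on what has been measured and on what is new or still open speak of the compounds shown alone.

Values so far in a functional assay on HL-60 cells (Homo sapiens) for cytotoxicity, read by MTT assay, with a stated time of 72 h; on this read-out higher numbers stand for weaker inhibition and lower numbers for stronger inhibition
- compound 1 `COc1cc(Nc2nc3ccccc3nc2S(=O)(=O)c2ccc(F)cc2)cc(OC)c1` gives 2360 nM
- compound 2 `Nc1ccc(Nc2nc3ccccc3nc2S(=O)(=O)c2ccc(F)cc2)cc1` gives 1620 nM

Compound 2 sits at 1620 nM within the scatter of compound 1, so no order can be read between the two. The next step leads to compound 3 `Nc1cccc(Nc2nc3ccccc3nc2S(=O)(=O)c2ccc(F)cc2)c1` and puts 3-aminophenyl in place of 4-aminophenyl on a nitrogen on an aromatic ring, with 3-aminophenyl in place of 4-aminophenyl on a nitrogen on an aromatic ring as the full difference. Going by the values given here, the one measured step at this place is a 1.5-fold lower number from compound 1 to compound 2 (0.16 log units; within the scatter) and it stays within the scatter. Among the compounds with values here, no measured compound carries 3-aminophenyl, so that step is the only guide. No change beyond the scatter is therefore expected in this assay for this swap. The expected step is a 1.1-fold higher number from compound 2 to compound 3 (0.05 log units; within the scatter) and it is small. Compound 3 is estimated at 1800 nM with an expected range from 700 nM to 4200 nM in this read-out.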

Compound 3, half-maximal inhibitory concentration: 4040 nM
Beside the measured number, compound 3's estimate is 2.2-fold (0.35 log units) below it; the measured number falls inside the stated range.
By their numbers in this assay, from the lowest: compounds 2, 1 and 3 (each within the scatter of the next, the first and the last beyond it).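

In this assay, going by these compounds alone, the swap of 4-aminophenyl for 3-aminophenyl on the nitrogen gives a 2.5-fold higher number from compound 2 to compound 3 (0.40 log units; beyond the scatter) and is the first step to pass the scatter, so with the same atoms joined differently this place still registers a change. Set against the 3,5-dimethoxyphenyl group, the 3-aminophenyl group gives a 1.7-fold higher number from compound 1 to compound 3 (0.23 log units; within the scatter) and no order can be read there, so only compound 2 and compound 3 separate among the three. Nothing measured here bears on the origin of this difference.

From the compounds shown here alone, whether a hydroxyl or a carboxylic acid in place of the amine on these phenyl groups would show a step of the same kind stays open. Also open, going by these compounds, is whether the gap between compound 2 and compound 3 holds in any other cell line.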